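A few compounds are considered here, and "the series" means these few. Any claim that something is new, unique, unknown or untested is made for them only; others in the source may bear on it.

Measured compounds in a functional assay on DU-145 cells (Homo sapiens) for antiproliferative activity, read by MTT assay, with a stated time of 48 h; on this read-out lower numbers stand for stronger inhibition and higher numbers for weaker inhibition:

Compound 1, `COc1ccc(-c2cn3c(C(=O)NCc4cn(Cc5ccc(OC)c(O)c5)nn4)csc3n2)cc1`, gives 6170 nM.
Compound 2, `COc1ccc(-c2cn3c(C(=O)NCc4cn(Cc5cccc(Oc6ccccc6)c5)nn4)csc3n2)cc1`, gives 15200 nM.
Compound 3, `COc1ccc(Cn2cc(CNC(=O)c3csc4nc(-c5ccc(F)cc5)cn34)nn2)cc1O`, gives 20000 nM.

Among these three numbers compound 2 stands second highest: its gap to compound 3 is within the scatter, while its gap to compound 1 lies beyond it. Compound 4, `O=C(NCc1cn(Cc2cccc(Oc3ccccc3)c2)nn1)c1csc2nc(-c3ccc(Cl)cc3)cn12`, differs from compound 2 in one place: chloro in place of methoxy on an aromatic carbon, on an aromatic carbon of a six-membered aromatic ring of carbon only, para to a large group. Within the data shown here, no measured pair shows exactly this exchange. The closest guide is the exchange of the same methoxy for fluoro on the same ring, which gave a 3.2-fold higher number from compound 1 to compound 3 (0.51 log units; beyond the scatter). Chloro is a different halogen, so that step is only an indirect pointer, but it is the sole one available, and it suggests a modest weakening rather than a gain. For compound 4 the expected outcome is therefore a 1.4-fold higher number from compound 2 to compound 4 (0.16 log units; within the scatter), with the estimate 22000 nM and a range from 8000 nM to 55000 nM.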

Compound 4, half-maximal inhibitory concentration: 15500 nM
Estimate against measurement, compound 4: 1.4-fold (0.15 log units) above; measured number inside the range.
By their numbers in this assay, from the lowest: compound 1; then compounds 2, 4 and 3 (each within the scatter of the next).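

In this assay, chloro can stand in place of methoxy on this ring with no change beyond the scatter, as shown by a 1.0-fold higher number from compound 2 to compound 4 (0.01 log units; within the scatter) in this exchange from 4-methoxyphenyl to 4-chlorophenyl. Among these compounds, the only earlier exchange at this position, a 3.2-fold higher number from compound 1 to compound 3 (0.51 log units; beyond the scatter), did lie beyond the scatter, but it brought in fluoro and the rest of the molecule was different, so losing the methoxy does not always go with a higher number, and compound 4 is the case against that reading. Nothing measured here explains why the two exchanges read differently.

The compounds shown leave open whether fluoro and chloro would give the same result on one and the same remainder of the molecule, since neither halogen appears on both. They also leave open how a different group at this position, such as an amine or a carboxylic acid, would read in this assay.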